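A few compounds are considered here, and "the series" means these few. Any claim that something is new, unique, unknown or untested is made for them only; others in the source may bear on it.

Compound 1 `OC(COCc1ccccc1)Cn1cc(CN2CCN(c3ccccc3)CC2)nn1` gives 37% in an assay on nucleic acid for inhibition of Nucleic Acid, read by fluorescence, tested at 100 uM; a lower number here means less inhibition, a higher number more inhibition at the concentration tested (going by the name of the read-out). Compound 2 `CCCCNC(=O)OCC(O)Cn1cc(CN2CCN(c3ccccc3)CC2)nn1` gives 11% in this assay. Compound 3 `CN(Cc1cn(CC(O)COCc2ccccc2)nn1)CC1CCCCC1` gives 6% in this assay.

The change butylcarbamoyl in place of benzyl on an oxygen on a saturated carbon made the step of a number 26 percentage points lower from compound 1 to compound 2 (beyond the scatter). Compound 4 `CCCCNC(=O)OCC(O)Cn1cc(CN(C)CC2CCCCC2)nn1` carries the same change, (butylcarbamoyl in place of benzyl on an oxygen on a saturated carbon), on the core of compound 3; how the core of compound 3 differs from the core of compound 1 is not broken down here. For compound 4 a step of a number 3 percentage points lower from compound 3 to compound 4 (within the scatter) is expected, much smaller than the earlier one, because compound 3 already sits at 6% in this assay and a percentage of inhibition can hardly fall much further from there. Compound 4 is therefore estimated at 3% in this assay, between -8% and 13%.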

Compound 4, a percentage reported as inhibition, at one concentration (the size of the read-out at that concentration, not a potency): 12%
Compound 4: the middle estimate sits 9 percentage points below what was measured; the range from low to high includes it.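

In this assay, putting butylcarbamoyl in place of benzyl gave a number 6 percentage points higher from compound 3 to compound 4 (within the scatter), so the change did not behave the same way on the two cores: the same change on two cores in this assay, a number 26 percentage points lower (beyond the scatter) from compound 1 to compound 2 and a number 6 percentage points higher (within the scatter) from compound 3 to compound 4, 32 percentage points apart, beyond the scatter of two such steps

The fall seen on the core of compound 1 therefore cannot be assumed to carry over to other cores in this series. Two pairs give no general rule, however, and they do not show which feature of the cores lies behind the difference.

Still open, on these data alone, is what a third core would do with this change. Also open, as far as these compounds go, is how other groups on that oxygen, such as a longer chain or a chain ending in an amine, would compare on either core.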